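The source may hold more compounds than are shown below. What is called first, only, known or untested is meant among the compounds shown, and "the series" means these compounds.

Measured compounds:
- compound 1, `[O-][n+]1nc(NCCO)[n+]([O-])c2ccccc21`: 22400 nM
- compound 2, `O=[N+]([O-])c1ccc(CNc2n[n+]([O-])c3ccccc3[n+]2[O-])cc1`: 7400 nM

Of the compounds shown here, two have been measured in a functional assay on PC-3 cells (Homo sapiens) for cytotoxicity, read by MTT assay, with a stated time of 48 h; on this read-out higher numbers stand for weaker inhibition and lower numbers for stronger inhibition. Compound 1 gives 22400 nM, the highest of the two numbers. Compound 2 gives 7400 nM; the gap between the two values is beyond the usual scatter, so compound 2 stands as the stronger of the pair. Going by the values given here, no step between directly comparable measured compounds is available, so nothing can be said yet about what a single change on the shared core does.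

The next compound, compound 3, `[O-][n+]1nc(Nc2ccccc2)[n+]([O-])c2ccccc21`, keeps the core of compound 1 and differs from it in one place: phenyl in place of 2-hydroxyethyl on a nitrogen on an aromatic ring. Both measured compounds carry a substituent on the same ring nitrogen, and the aryl-bearing compound 2 sits at the lower value, whereas the hydroxyalkyl-bearing compound 1 sits at the higher one. On that basis, the step of a 2.5-fold lower number from compound 1 to compound 3 (0.40 log units; beyond the scatter) is expected to run toward a lower number, of moderate size, rather than to stay within the scatter. Compound 3 is therefore estimated at 9000 nM, with a range from 3000 nM to 30000 nM in this assay.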

Compound 3, half-maximal inhibitory concentration: 17000 nM
The estimate for compound 3 lay 1.9-fold (0.28 log units) below the measured number, and the stated range covers the measured number.
By their numbers in this assay, from the lowest: compound 2; then compounds 3 and 1 (each within the scatter of the next).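

In this assay, going by these compounds alone, the exchange of 2-hydroxyethyl for phenyl on a nitrogen on an aromatic ring gives a 1.3-fold lower number from compound 1 to compound 3 (0.12 log units; within the scatter) and is therefore the first direct reading at this position. It shows that a chain with no ring, carrying one hydrogen-bond donor and one hydrogen-bond acceptor, can be replaced by a six-membered aromatic ring of carbon only, with neither donor nor acceptor, without taking the read-out beyond the usual scatter. No measured property or other supporting data bear on this result, so the step stands without an explanation.

Still open, going by these compounds, is whether a longer alkyl chain, a plain benzyl group, or a phenyl ring carrying a halogen, a methoxy group or an amine on the same nitrogen would give a step beyond the scatter on the shared core. Also open, on these data alone, is whether this small step would hold in other cell lines or at other exposure times, since a single step in a single assay cannot settle how general it is.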